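This account rests on a few compounds, and the source may have more. Where it says the series, first, only, none or still open, it means among the compounds named here.

Compound 1 `COC(C)(C)/C=C/C/C(C)=C/Cc1c(O)ccc2c1O[C@H](c1ccc(O)cc1)CC2=O`: > 10000 nM
Compound 2 `C=C(CCC=C(C)C)C(O)Cc1c(O)ccc2c1O[C@H](c1ccc(O)cc1)CC2=O`: > 10000 nM

Both results come from a functional assay on HepG2 cells (Homo sapiens) for cytotoxicity, read by MTT assay; a lower number here means a stronger inhibitor, a higher number a weaker inhibitor. For compound 1 the result > 10000 nM is a limit of the assay rather than a measured number. For compound 2 the result > 10000 nM is likewise a limit. Compound 1 thus stands at the limit at which every shown value sits (the limit of > 10000 nM in this assay, at which 2 of the 2 values shown sit), so nothing separates it from compound 2 on these numbers. Compound 3 `COC(C=C(C)C)C/C(C)=C/Cc1c(O)ccc2c1O[C@H](c1ccc(O)cc1)CC2=O` is the compound still to be measured in this assay. It differs from compound 1 in one place: 1-methoxy-3-methylbut-2-en-1-yl in place of 3-methoxy-3-methylbut-1-en-1-yl on a saturated chain carbon bound to a double-bonded chain carbon. For the measured compounds named here, no step between two measured compounds is available, so the size of this change cannot be read from the data. The expected step that the limit leaves unreadable from compound 1 to compound 3 is none beyond the scatter. Compound 3 is expected to give 20000 nM in this assay, within a range from 5000 nM to 100000 nM, most likely again as a limit.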

Compound 3, half-maximal inhibitory concentration: > 10000 nM
Compound 3: a limit, no number (the forecaster's own chance of this, stated with the estimate: 80%); the middle value lies beyond the limit too.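

No step from compound 1 to compound 3 can be read, because in this assay each result is a limit and not a measured number: the limit of > 10000 nM in this assay, at which 3 of the 3 values shown sit.

The compounds shown leave open whether 1-methoxy-3-methylbut-2-en-1-yl in place of 3-methoxy-3-methylbut-1-en-1-yl changes cytotoxicity at all, and at what concentration, if any, compound 1, compound 2 or compound 3 would harm these cells.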